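This account rests on a few compounds, and the source may have more. Where it says the series, first, only, none or still open, it means among the compounds named here.

Measured compounds:
compound 1, `CC(C)(C)c1ccc(Cn2cc(-c3cn([C@H]4C[C@H](O)[C@@H](CO)O4)c(=O)[nH]c3=O)nn2)cc1`, 92.3%
compound 2, `CCCCc1ccc(-c2cc(-c3cn([C@H]4C[C@H](OC(C)=O)[C@@H](COC(C)=O)O4)c(=O)[nH]c3=O)on2)cc1`, 30.4%
compound 3, `CC(=O)OC[C@H]1O[C@@H](n2cc(-c3cc(C)no3)c(=O)[nH]c2=O)C[C@@H]1OC(C)=O`, 92.4%

In a functional assay on PC-3 cells (Homo sapiens) for cytotoxicity, read by sulforhodamine B assay, tested at 10 uM (on this read-out lower numbers stand for less inhibition and higher numbers for more inhibition at the one concentration tested (going by the name of the read-out)), compound 3 stands highest of the three numbers, though compound 1 lies within the scatter of it, while compound 2 lies far lower. Compound 4, `CCCc1cc(-c2cn([C@H]3C[C@H](OC(C)=O)[C@@H](COC(C)=O)O3)c(=O)[nH]c2=O)on1`, differs from compound 3 by ethyl in place of hydrogen on a saturated chain carbon bound to an aromatic carbon. Among the compounds with values here, only one measured step bears on this: a number 62 percentage points higher from compound 2 to compound 3 (beyond the scatter), where the smaller group on the same aromatic carbon gave the larger number. Growing methyl to propyl moves partway back toward the bulkier group of compound 2, so a moderate drop is expected, a number 20.4 percentage points lower from compound 3 to compound 4 (beyond the scatter), but smaller than that step, since the group stays short. Compound 4 is therefore estimated at 72%, in a range from 45% to 95%.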

Compound 4, a percentage reported as inhibition, at one concentration (the size of the read-out at that concentration, not a potency): 88.1%
Compound 4: middle estimate off by 16.1 percentage points, on the low side; low and high end bracket the measured number.
By their numbers in this assay, from the lowest: compound 2; then compounds 4, 1 and 3 (each within the scatter of the next).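

In this assay this position accepts more than methyl: propyl in place of methyl gives a number 4.3 percentage points lower from compound 3 to compound 4 (within the scatter), so the two cannot be told apart. Propyl still stands well clear of 4-butylphenyl, with a number 57.7 percentage points higher from compound 2 to compound 4 (beyond the scatter), so the low number of compound 2 goes with that larger group and not with every extension at this place. No measurement shown gives a reason for this. On these data alone, what remains open is where the number begins to fall between propyl and 4-butylphenyl, for instance with a hexyl chain or a plain phenyl ring. An amine at the end of the chain is also untested among these compounds.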